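A Second Bromo on Compound 3

The source may report more compounds than this note shows. Statements on the series, on what has been measured and on what is new or still open speak of the compounds shown alone.

Three compounds have been measured in a functional assay on A549 cells (Homo sapiens) for antiproliferative activity, read by MTT assay, with a stated time of 72 h (on this read-out lower numbers stand for stronger inhibition and higher numbers for weaker inhibition), with these results:
- compound 1 `N#Cc1ccc(/C=N/NC(=O)Nc2ccc(Oc3ccnc4[nH]ccc34)c(F)c2)cc1` (1360 nM)
- compound 2 `O=C(N/N=C/c1ccc(Cl)c(Cl)c1)Nc1ccc(Oc2ccnc3[nH]ccc23)c(F)c1` (2650 nM)
- compound 3 `O=C(N/N=C/c1ccc(O)c(Br)c1)Nc1ccc(Oc2ccnc3[nH]ccc23)c(F)c1` (9250 nM)

Compound 3 stands highest of the three: a 3.5-fold higher number from compound 2 to compound 3 (0.54 log units; beyond the scatter) and a 6.8-fold higher number from compound 1 to compound 3 (0.83 log units; beyond the scatter) separate it from the others. The next compound is compound 4 `O=C(N/N=C/c1cc(Br)c(O)c(Br)c1)Nc1ccc(Oc2ccnc3[nH]ccc23)c(F)c1` and its difference from compound 3 is bromo in place of hydrogen on an aromatic carbon in the form of bromo in place of hydrogen on an aromatic carbon, ortho to a hydroxy group. This turns 3-bromo-4-hydroxyphenyl into 3,5-dibromo-4-hydroxyphenyl.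

Among the compounds with values here, no measured step adds a single bromo. Within the data shown here, the only guides are exchanges of the whole aryl group, where a 1.9-fold higher number from compound 1 to compound 2 (0.29 log units; within the scatter) stayed small while a 3.5-fold higher number from compound 2 to compound 3 (0.54 log units; beyond the scatter) and a 6.8-fold higher number from compound 1 to compound 3 (0.83 log units; beyond the scatter) were modest. This single addition is a smaller change than those exchanges, so only a slight shift towards a lower number is expected. The step expected in this assay is small, a 1.4-fold lower number from compound 3 to compound 4 (0.15 log units; within the scatter) by estimate. Compound 4 is estimated to read 6500 nM with an expected range of 2200 nM to 19000 nM on this read-out.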

Compound 4, half-maximal inhibitory concentration: 16200 nM
Beside the measured number, compound 4's estimate is 2.5-fold (0.40 log units) below it, within the range that was stated.
By their numbers in this assay, from the lowest: compounds 1 and 2 (each within the scatter of the next); then compounds 3 and 4 (each within the scatter of the next).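

In this assay, within the data shown here, the single added bromo, ortho to a hydroxy group, gives a 1.8-fold higher number from compound 3 to compound 4 (0.24 log units; within the scatter) as the first step that changes one atom on the aryl ring, so 3-bromo-4-hydroxyphenyl and 3,5-dibromo-4-hydroxyphenyl cannot be told apart here. Measured against the other aryl groups, the dibromo ring shows a 6.1-fold higher number from compound 2 to compound 4 (0.79 log units; beyond the scatter) and a 12-fold higher number from compound 1 to compound 4 (1.08 log units; beyond the scatter), the second being the only large step among the compounds shown. No measurement available here gives a reason for any of these steps.

The compounds shown leave open how a chloro or a methyl would read in place of this second bromo. They also leave open whether the two bromo groups would read the same with a methoxy or an amine in place of the hydroxy group.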